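Amide aryl swap, bromo to methoxy: cytotoxicity notes

The compounds below may be only part of what the source reports. "The series", "measured", "known", "first", "only" and "open" are said of these compounds alone.

Measured so far:
compound 1, `O=C(NC1CCCCC1)c1c(NO)cc(-c2ccccc2)oc1=O`: 10500 nM
compound 2, `O=C(Nc1ccc(Br)cc1)c1c(NO)cc(-c2cccs2)oc1=O`: > 20000 nM (a limit of the assay, not a number)

Of the compounds shown here, two have been tested in an ADME assay on Huh-7 cells (Homo sapiens) for cytotoxicity, with a stated time of 3 days; on this read-out lower numbers stand for higher toxicity in this test and higher numbers for lower toxicity in this test. Compound 1 gives 10500 nM. Compound 2 returns only > 20000 nM, which is a limit of the assay and not a number. Compound 2 thus sits at the limit of > 20000 nM in this assay, at which 1 of the 2 values shown sits, the less toxic end of what has been measured so far. Among the compounds with values here, no pair of measured compounds differs in a single place, so no step size for this kind of change is known from the series itself.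

Compound 3, `COc1ccc(NC(=O)c2c(NO)cc(-c3cccs3)oc2=O)cc1`, is not yet measured in this assay. It differs from compound 2 by methoxy in place of bromo on an aromatic carbon. With compound 2 already at the limit, the change is expected to move the read-out by no more than the usual scatter. The expected step that the limit leaves unreadable from compound 2 to compound 3 is, in effect, none. Compound 3 is therefore estimated at 25000 nM, within 10000 nM to 60000 nM, and it may well again return only a limit rather than a number.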

Compound 3, half-maximal cytotoxic concentration: > 20000 nM
Compound 3: only a limit was reported; the forecaster's own chance of this, stated with the estimate: 65%; the middle value does not contradict the limit.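

Compound 2 and compound 3 both return only a limit of the assay in this assay, so the step between them cannot be read: the limit of > 20000 nM in this assay, at which 2 of the 3 values shown sit. The compounds shown leave open whether 4-bromophenyl to 4-methoxyphenyl moves this read-out at all, and, if it does, in which direction and how far.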